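Swapping a Fluorophenyl for a Bromophenyl at the Ceiling

The compounds below may be only part of what the source reports. "The series", "measured", "known", "first", "only" and "open" are said of these compounds alone.

Three compounds share one core and differ only in the fluorophenyl ring carried on a nitrogen. Compound 1 `Fc1ccc(Nc2nc(-c3cccc(F)c3)nc3ccc(F)cc23)cc1` gives > 50000 nM in a functional assay on MCF7 cells (Homo sapiens) for cytotoxicity, read by MTT assay, with a stated time of 48 h (on this read-out lower numbers stand for stronger inhibition and higher numbers for weaker inhibition), a limit of the assay rather than a number. Compound 2 `Fc1cccc(Nc2nc(-c3cccc(F)c3)nc3ccc(F)cc23)c1` reaches 48700 nM in this assay. Compound 3 `Fc1cccc(-c2nc(Nc3ccccc3F)c3cc(F)ccc3n2)c1` returns > 50000 nM, again a limit. The steps of an at least 1.0-fold lower number from compound 1 to compound 2 (0.01 log units; that floor lies within the scatter) and an at least 1.0-fold higher number from compound 2 to compound 3 (0.01 log units; that floor lies within the scatter) hardly move, and a step that the two limits leave unreadable from compound 1 to compound 3 cannot be read; the limit of > 50000 nM in this assay, at which 2 of the 3 values shown sit, marks where most of the series sits. Compound 4 `Fc1cccc(-c2nc(Nc3ccc(Br)cc3)c3cc(F)ccc3n2)c1` carries 4-bromophenyl in place of 2-fluorophenyl on a nitrogen on an aromatic ring. Because the limit of > 50000 nM in this assay, at which 2 of the 3 values shown sit, holds two of three values, compound 4 is expected to stay at that ceiling as well. The expected step is a number no higher from compound 3 to compound 4 (the limit leaves the size open). Compound 4 is therefore estimated at 50000 nM, within a range of 20000 nM to 100000 nM.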

Compound 4, half-maximal inhibitory concentration: > 50000 nM
Compound 4 ended at the assay's limit; the forecaster's own chance of this, stated with the estimate: 70%; the middle value lies on the limit itself.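

The change from fluorine to bromine on this ring does not lift the series off its ceiling: in this assay compound 4 gives > 50000 nM, which is a limit of the assay. For the compounds shown here, the one readable step is an at least 1.0-fold higher number from compound 2 to compound 4 (0.01 log units; that floor lies within the scatter), while the steps to compound 4 from compound 1 and compound 3 cannot be read. A 4-bromophenyl on this nitrogen therefore brings no readable gain, and the values gather at one point: the limit of > 50000 nM in this assay, at which 3 of the 4 values shown sit.

On these data alone, whether any group at this position can clearly lower the number stays open. A 4-aminophenyl ring, a 4-carboxyphenyl ring or a longer chain such as hexyl could answer that.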